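Isobutoxy to ethoxy: working notes on the series

The compounds below may be only part of what the source reports. "The series", "measured", "known", "first", "only" and "open" are said of these compounds alone.

Measured so far in a physicochemical assay for lipophilicity, at pH 7.4; a lower number here means a more polar compound, a higher number a more lipophilic compound
Compound 1 `Cc1cc(NC(=O)C2CCCO2)nn1Cc1cc(Cl)ccc1OCc1ccccc1` gives > 3.7 (a limit, not a number)
Compound 2 `Cc1cc(NC(=O)OCC(C)C)nn1Cc1cc(Cl)ccc1OCc1ccccc1` gives 3.3

Among the compounds with values here, compound 2 at 3.3 holds the only actual number so far. The value of compound 1 is a limit. Compound 3 `CCOC(=O)Nc1cc(C)n(Cc2cc(Cl)ccc2OCc2ccccc2)n1` differs from compound 2 by methyl in place of isopropyl on a saturated chain carbon bound to an oxygen next to a carbonyl group, so that ethoxy stands in place of isobutoxy. Within the data shown here, one measured step bears on this, a number at least 0.40 log units lower from compound 1 to compound 2 (beyond the scatter), with isobutoxy in place of oxolan-2-yl on a carbonyl carbon. That is a different change, so it guides the size only loosely. A modest move to a lower number in this assay is expected, slightly beyond the scatter. The expected step is a number 0.50 log units lower from compound 2 to compound 3 (beyond the scatter) in this reading. For compound 3 the estimate is 2.8, with an expected range from 2.4 to 3.2.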

Compound 3, distribution coefficient: > 3.7
Compound 3 gave a limit, no number; the forecaster's own chance of this, stated with the estimate: 2%; at least 0.90 log units between middle value and limit.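

Methyl in place of isopropyl on a saturated chain carbon bound to an oxygen next to a carbonyl group, which turns isobutoxy into ethoxy, gives a number at least 0.40 log units higher from compound 2 to compound 3 (beyond the scatter) in this assay. Within the data shown here, this single pair shows that, at this position, a chain with fewer carbons can go with a higher number, and compound 2 is the only compound of the three with a number. The value of compound 3, > 3.7, is a limit and not a number, so the step has a lower bound and no upper one, and the series now sits mostly at that ceiling: the limit of > 3.7 in this assay, at which 2 of the 3 values shown sit.

The step between compound 1 and compound 3 cannot be read, since both values are limits. Also open, from the compounds shown here alone, is how a propyl chain or an amine in place of ethoxy would read in this assay.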